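A Substituent Swap from Compound 2 to Compound 4

A few compounds are considered here, and "the series" means these few. Any claim that something is new, unique, unknown or untested is made for them only; others in the source may bear on it.

Measured so far:
compound 1 `COc1ccc(Cn2cc(CN(Cc3cn(S(=O)(=O)c4ccc(C)cc4)c4ccccc34)S(=O)(=O)c3ccc(C)cc3)nn2)c(OC)c1`: 7.6%
compound 2 `Cc1ccc(S(=O)(=O)N(Cc2cn(Cc3cccc(F)c3F)nn2)Cc2cn(S(=O)(=O)c3ccc(C)cc3)c3ccccc23)cc1`: 71.5%
compound 3 `Cc1ccc(S(=O)(=O)n2cc(CN(Cc3cn(Cc4cccc(F)c4F)nn3)C(=O)C(F)(F)F)c3ccccc32)cc1`: 31.9%

Of the compounds shown here, three have been tested in a functional assay on 3T3-L1 cells (Mus musculus) for inhibition, with a stated time of 20 min, tested at 20 uM; on this read-out higher numbers stand for more inhibition at the one concentration tested (going by the name of the read-out) and lower numbers for less inhibition. Compound 2 stands highest of the three numbers. Its nearest neighbour is reached by the step of a number 39.6 percentage points lower from compound 2 to compound 3 (beyond the scatter), and the furthest by the reverse of the step of a number 63.9 percentage points higher from compound 1 to compound 2 (beyond the scatter); both steps lie beyond the scatter.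

Compound 4 `COc1cc(OC)c(Cn2cc(CN(Cc3cn(S(=O)(=O)c4ccc(C)cc4)c4ccccc34)S(=O)(=O)c3ccc(C)cc3)nn2)c(OC)c1` has not yet been measured. It differs from compound 2 in one place: 2,4,6-trimethoxyphenyl in place of 2,3-difluorophenyl on a saturated chain carbon bound to an aromatic nitrogen. The measured step that bears on this is a number 63.9 percentage points higher from compound 1 to compound 2 (beyond the scatter), a large rise when a methoxy-bearing phenyl at the same place gave way to the difluorophenyl. The present change runs the other way, from the difluorophenyl back to a phenyl bearing methoxy groups, now three of them. The step of a number 39.6 percentage points lower from compound 2 to compound 3 (beyond the scatter) concerns the amine nitrogen and does not bear on it. A large fall in this assay is therefore expected. Compound 4 is estimated at 12%, in a range from 0% to 35%. The expected step is a number 59.5 percentage points lower from compound 2 to compound 4 (beyond the scatter).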

Compound 4, a percentage reported as inhibition, at one concentration (the size of the read-out at that concentration, not a potency): -22%
For compound 4 the middle estimate is 34 percentage points above the measured one, and the stated range ends above it.
By their numbers in this assay, from the lowest: compound 4; then compound 1; then compound 3; then compound 2.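

In this assay, the place on a saturated chain carbon bound to an aromatic nitrogen can take the read-out below zero: compound 4 gives -22%. Exchanging 2,3-difluorophenyl for 2,4,6-trimethoxyphenyl produces a number 93.5 percentage points lower from compound 2 to compound 4 (beyond the scatter), the largest step among the compounds shown. The methoxy-bearing groups also differ from each other, since methoxy in place of hydrogen on an aromatic carbon gives a number 29.6 percentage points lower from compound 1 to compound 4 (beyond the scatter), so the number at this place depends on the methoxy pattern as well as on the exchange for the difluorophenyl.

Nothing available explains why the number moves in this way or what a value below zero reflects. On these data alone, it remains open where an unsubstituted phenyl or a hydroxyphenyl would fall at this place, and whether 2,4,6-trimethoxyphenyl would have the same effect with (trifluoromethyl)carbonyl on the amine nitrogen.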